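The compounds below may be only part of what the source reports. "The series", "measured", "known", "first", "only" and "open" are said of these compounds alone.

Measured compounds in a functional assay on A549 cells (Homo sapiens) for inhibition, read by MTT assay, with a stated time of 24 h, tested at 5 uM; a lower number here means less inhibition of growth, a higher number more inhibition of growth at the concentration tested:

- compound 1, `CS(=O)(=O)c1ccc(-c2cnc3[nH]cc(-c4nnc(-c5ccncc5)o4)c(=O)c3c2)cc1`, gives 6.76%
- compound 2, `CS(=O)(=O)c1ccc(-c2cnc3[nH]cc(-c4nnc(-c5ccc(Cl)cc5)o4)c(=O)c3c2)cc1`, gives 23.8%

Among the compounds with values here, compound 2 stands highest of the two numbers in this assay, with compound 1 the only neighbour; the single step measured, a number 17 percentage points higher from compound 1 to compound 2 (beyond the scatter), exchanges pyridin-4-yl for 4-chlorophenyl on an aromatic carbon and lies beyond the scatter.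

Compound 3, `Cc1ccc(-c2nnc(-c3c[nH]c4ncc(-c5ccc(S(C)(=O)=O)cc5)cc4c3=O)o2)cc1`, is the next member. It differs from compound 2 by methyl in place of chloro on an aromatic carbon: one heavy atom leaves, one heavy atom enters, on an aromatic carbon of a six-membered aromatic ring of carbon only, para to a large group, so that 4-chlorophenyl becomes 4-methylphenyl.

Within the data shown here, no measured step covers this exchange. Among the measured compounds shown here, the only step available, from compound 1 to compound 2, concerns a different change and is modest in size, so it gives no more than an upper sense of the scale to expect. For the chloro to methyl exchange, a step of a number 5.8 percentage points lower from compound 2 to compound 3 (within the scatter) is expected, within or near the scatter, with compound 3 estimated at 18% in this assay, between 5% and 35%.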

Compound 3, percent growth inhibition at one concentration: 6.69%
Compound 3: the middle estimate sits 11.3 percentage points above what was measured; low and high end bracket the measured number.
By their numbers in this assay, from the lowest: compounds 3 and 1 (each within the scatter of the next); then compound 2.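

In this assay, the exchange of chloro for methyl on an aromatic carbon, para to a large group, gives a number 17.1 percentage points lower from compound 2 to compound 3 (beyond the scatter), so a change of one heavy atom at this position is enough to move the read-out beyond the scatter. With a number 0.1 percentage points lower from compound 1 to compound 3 (within the scatter), 4-methylphenyl and pyridin-4-yl cannot be told apart here, so the step from pyridin-4-yl to 4-chlorophenyl cannot be credited to the phenyl ring alone; among these three compounds, compound 2 is the only one whose steps to both others lie beyond the scatter. Nothing available bears on the reason for this result.

From the compounds shown here alone, it remains open whether the higher number in compound 2 is particular to chloro or is shared by other groups at this position, such as fluoro, bromo, trifluoromethyl or methoxy. An amine or a carboxylic acid at this position is also an open case, as is the behaviour of all three compounds at other concentrations.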